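The compounds below may be only part of what the source reports. "The series", "measured", "known", "first", "only" and "open" are said of these compounds alone.

Measured compounds in a functional assay on KYSE-70 cells for antiproliferative activity against KYSE-70 cell line (Homo sapiens), read by MTT assay, with a stated time of 72 h; on this read-out lower numbers stand for stronger inhibition and higher numbers for weaker inhibition:
Compound 1 `O=C(Nc1ccc(OC(F)(F)F)cc1)c1cc(=O)[nH]c2cc(Br)ccc12` gives > 20000 nM, a limit of the assay.
Compound 2 `COc1ccc2c(C(=O)Nc3cc(F)cc(F)c3)cc(=O)[nH]c2c1` gives > 20000 nM, a limit of the assay.
Compound 3 `CC(=O)c1ccc(-c2ccc3c(C(=O)Nc4cccc(F)c4)cc(=O)[nH]c3c2)cc1` gives > 20000 nM, a limit of the assay.

Compound 3 therefore stands at a limit in this assay rather than at a number, and it shares this position with both other measured compounds: the limit of > 20000 nM in this assay, at which 3 of the 3 values shown sit. For the measured compounds named here, none of the three shows a measurable half-maximal inhibitory concentration, so no step between measured compounds can be given, and nothing in the data separates one from another.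

Compound 4 `Cc1cc(-c2ccc3c(C(=O)Nc4cccc(F)c4)cc(=O)[nH]c3c2)c(C)cc1F` differs from compound 3 in a single place: 4-fluoro-2,5-dimethylphenyl in place of 4-acetylphenyl on an aromatic carbon. The shared core of compound 3 and the amide-linked fluorophenyl ring are kept.

With every measured compound at the limit, the expected step that the limit leaves unreadable from compound 3 to compound 4 is none beyond the usual scatter, since the starting point itself is only a limit. Compound 4 is thus estimated at 30000 nM, with a range from 8000 nM to 100000 nM, and most likely it too will be reported only as a limit.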

Compound 4, half-maximal inhibitory concentration: > 20000 nM
Compound 4: no number, only a limit (the forecaster's own chance of this, stated with the estimate: 85%); the middle value is on the limit's open side.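

In this assay compound 4 gives > 20000 nM, which is a limit of the assay. For the compounds shown here, compound 3 also stands at a limit, so no step from compound 3 to compound 4 can be read. The compounds shown leave open what structure, if any, gives a measurable half-maximal inhibitory concentration here: the limit of > 20000 nM in this assay, at which 4 of the 4 values shown sit.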